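Carboxy to methylcarbamoyl on the shared core

The source may report more compounds than this note shows. Statements on the series, on what has been measured and on what is new or still open speak of the compounds shown alone.

Three compounds of this series have numbers in an assay on COS-7 cells for inhibition of patatin-like phospholipase domain-containing protein 2 (Mus musculus), tested at 200 uM; on this read-out lower numbers stand for less inhibition and higher numbers for more inhibition at the one concentration tested (going by the name of the read-out). Compound 1 `CCOC(=O)c1ccnc(-c2ccc(OCC)cc2)c1` gives 87% in this assay. Compound 2 `CCOC(=O)c1cccc(-c2ccc([N+](=O)[O-])cc2)c1` gives 63% in this assay. Compound 3 `CCOc1ccc(-c2cccc(C(=O)O)c2)cc1` gives 23% in this assay, the lowest of the three numbers; the gap to compound 2 and the larger gap to compound 1 both lie beyond the usual scatter. No two of these compounds differ in a single place, so no single-change step can be read from them.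

Compound 4 `CCOc1ccc(-c2cccc(C(=O)NC)c2)cc1` is not yet measured. Relative to compound 3 the change is methylamino in place of hydroxy on a carbonyl carbon. The carboxy group of compound 3 sits where the methylcarbamoyl group of compound 4 sits, on a carbonyl carbon attached to an aromatic carbon of the shared core.

The step from compound 3 to compound 4 is expected to be upward by a number 22 percentage points higher from compound 3 to compound 4 (beyond the scatter), a change beyond the scatter but short of the top of the series, because the carboxy compound 3 gives 23% while the compounds without a carboxy group, compound 1 and compound 2, give higher numbers. The estimate for compound 4 in this assay is 45%, within a range from 20% to 70%.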

Compound 4, a percentage reported as inhibition, at one concentration (the size of the read-out at that concentration, not a potency): 40%
Beside the measured number, compound 4's estimate is 5 percentage points above it; low and high end bracket the measured number.
By their numbers in this assay, from the lowest: compound 3; then compound 4; then compound 2; then compound 1.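

In this assay, among these compounds, the first single-change step can be read: methylamino in place of hydroxy on a carbonyl carbon attached to an aromatic carbon of the shared core gives a number 17 percentage points higher from compound 3 to compound 4 (beyond the scatter) and so lies beyond the scatter, though it is modest in size. Among the compounds shown here, this place therefore responds to the group on the carbonyl carbon, which the earlier compounds could not show, since none of them formed a single-change pair. The response appears with the counted hydrogen-bond donors and acceptors of the leaving and entering groups unchanged, and no measurement at hand explains the step.

Steps from compound 3 or compound 4 to compound 1 and compound 2 cannot be read, as those pairs differ in more than one place, so the separate contributions of the other parts of the shared core remain unresolved. From the compounds shown here alone, whether the gain belongs to the methyl group or to the nitrogen also remains open, and plain amino, dimethylamino or a longer chain such as ethylamino on the same carbonyl carbon would separate the two.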